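Diethylamino to dipropylamino on two related cores

The source may hold more compounds than are shown below. What is called first, only, known or untested is meant among the compounds shown, and "the series" means these compounds.

Measured compounds:
Compound 1 `CCN(CC)CC#CCCCC1(C(O)(c2ccccc2)c2ccccc2)SCCCS1` gives 810 nM in a functional assay for antagonist activity, with Cavia porcellus as the target; on this read-out lower numbers stand for stronger inhibition and higher numbers for weaker inhibition.
Compound 2 `CCCN(CC#CCCCC1(C(O)(c2ccccc2)c2ccccc2)SCCCS1)CCC` gives 560 nM in this assay.
Compound 3 `CCN(CC)CC#CCC1(c2ccccc2)SCCCS1` gives 4270 nM in this assay.

Compound 1 and compound 2 share one core and differ by dipropylamino in place of diethylamino on a saturated chain carbon bound to a triple-bonded carbon. This change gave a 1.4-fold lower number from compound 1 to compound 2 (0.16 log units; within the scatter), so the two numbers cannot be told apart with confidence.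

Compound 3 carries a second core. The difference between the two cores is not broken down here. In this assay compound 3 gives the highest number of the three measured compounds, and its gaps to compound 1 and to compound 2 are both beyond the usual scatter.

Compound 4 `CCCN(CC#CCC1(c2ccccc2)SCCCS1)CCC` is not yet measured. It differs from compound 3 by dipropylamino in place of diethylamino on a saturated chain carbon bound to a triple-bonded carbon, the same change that turns compound 1 into compound 2, and made at the same kind of place. Among the measured compounds shown here, with only one measured example of the change, the expectation for compound 4 is that the number stays close to that of compound 3.

The expected step is a 1.4-fold lower number from compound 3 to compound 4 (0.15 log units; within the scatter), which rests on the measured step for the same change, a 1.4-fold lower number from compound 1 to compound 2 (0.16 log units; within the scatter).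

For compound 4 the expected value in this assay is 3000 nM, with an estimated range from 1400 nM to 6500 nM.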

Compound 4, antagonist equilibrium constant: 1010 nM
Compound 4: middle estimate off by 3.0-fold (0.47 log units), on the high side; the measured number lies below the stated range.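

In this assay, dipropylamino in place of diethylamino on a saturated chain carbon bound to a triple-bonded carbon gave a 4.2-fold lower number from compound 3 to compound 4 (0.63 log units; beyond the scatter), so on the core of compound 3 the change has a readable effect on the number. The size of the step did not carry over from the other core, and a step read on one core would have been a poor guide to the step on the other: the same change on two cores in this assay, a 1.4-fold lower number (0.16 log units; within the scatter) from compound 1 to compound 2 and a 4.2-fold lower number (0.63 log units; beyond the scatter) from compound 3 to compound 4, 2.9-fold (0.47 log units) apart, beyond the scatter of two such steps. Among the compounds shown here, this shows that the effect of the change depends on the core in these two pairs, but it does not show which difference between the cores matters or why, and with only two pairs it sets no rule for the series; nor does it show a shared direction, since the step on the core of compound 1 lies within the scatter.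

From the compounds shown here alone, it remains open whether dimethylamino or dibutylamino on the same chain carbon would extend the trend on the core of compound 3 or leave the number flat on the core of compound 1. Also open, going by these compounds, is which part of the core governs the size of the step, a question that a core differing from either one in a single place could address.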